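The compounds below may be only part of what the source reports. "The series", "measured", "known", "first", "only" and "open" are said of these compounds alone.

Three compounds share one core and differ only in the group attached to an aromatic carbon of its fused ring. Compound 1 `C=CCO/N=C(/N)c1ccc2[nH]c(-c3cccc(-c4ccccc4O)c3O)cc2c1` carries the smallest such group. In a physicochemical assay for solubility, in phosphate buffer, at pH 7.4 (a higher number here means a more soluble compound, a lower number a less soluble compound), compound 1 gives 24000 nM. Compound 2 `CC(C)(C)ONC(=N)c1ccc2[nH]c(-c3cccc(-c4ccccc4O)c3O)cc2c1` has a tert-butoxy group on the amidine nitrogen. In this assay compound 2 gives < 10000 nM, a limit of the assay and not a number. Compound 3 `CCOC(=O)NC(=N)c1ccc2[nH]c(-c3cccc(-c4ccccc4O)c3O)cc2c1` has an ethoxycarbonyl group there. In this assay compound 3 gives < 10000 nM, again a limit rather than a number. Compound 3 therefore stands only at a limit, and the limit of < 10000 nM in this assay, at which 2 of the 3 values shown sit, shows it is not alone there. The measured steps were an at least 2.4-fold lower number from compound 1 to compound 2 (0.38 log units; beyond the scatter) and an at least 2.4-fold lower number from compound 1 to compound 3 (0.38 log units; beyond the scatter), while a step that the two limits leave unreadable from compound 2 to compound 3. Compound 4 `N/C(=N/C(=O)OCC(Cl)(Cl)Cl)c1ccc2[nH]c(-c3cccc(-c4ccccc4O)c3O)cc2c1` differs from compound 3 by a group of 11 heavy atoms (4 carbon, 2 nitrogen, 2 oxygen, 3 chlorine; no ring) in place of a group of 8 heavy atoms (4 carbon, 2 nitrogen, 2 oxygen; no ring), on an aromatic carbon. Within the data shown here, no measured step involves three chlorines, and the two limit values carry no size. Compound 4 is expected to stay near or under the limit, estimated at 4000 nM, ranging from 800 nM to 12000 nM. The step that the limit leaves unreadable from compound 3 to compound 4 is expected to be small or downward.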

Compound 4, solubility: < 10000 nM
Compound 4 ended at the assay's limit (the forecaster's own chance of this, stated with the estimate: 80%); the middle value is on the limit's open side.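

In place of allyloxy, the (2,2,2-trichloroethoxy)carbonyl group gives an at least 2.4-fold lower number from compound 1 to compound 4 (0.38 log units; beyond the scatter), so a third, chlorine-bearing group at this position also falls clearly short of compound 1 in this assay. Compound 4 gives a limit of the assay and not a number, and it joins the other compounds stopped there: the limit of < 10000 nM in this assay, at which 3 of the 4 values shown sit. The steps from compound 2 and compound 3 to compound 4 cannot be read, so putting three chlorines on the ethoxycarbonyl group has no measurable size here.

Among these compounds, with compound 1 as the only readable value, these compounds cannot separate the size of the group from its kind. From the compounds shown here alone, a hydroxy group or a plain amine at this place, or a carbamate ending in a carboxylic acid, remains open.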